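Replacing Bromo with Methyl on a Shared Core

The source may report more compounds than this note shows. Statements on the series, on what has been measured and on what is new or still open speak of the compounds shown alone.

Three compounds share one core and differ only in the group on an aromatic carbon. In a functional assay on HeLa cells (Homo sapiens) for antiproliferative activity, with a stated time of 48 h (on this read-out higher numbers stand for weaker inhibition and lower numbers for stronger inhibition), the fluoro compound 1 `C=C(Br)C(=O)Nc1ccc(/C=C/C(=O)c2ccc(F)cc2)cc1` gives 1400 nM, the chloro compound 2 `C=C(Br)C(=O)Nc1ccc(/C=C/C(=O)c2ccc(Cl)cc2)cc1` gives 1600 nM, and the bromo compound 3 `C=C(Br)C(=O)Nc1ccc(/C=C/C(=O)c2ccc(Br)cc2)cc1` gives 1000 nM. Compound 3 therefore does not stand apart from the other two: the measurements show a 1.4-fold lower number from compound 1 to compound 3 (0.15 log units; within the scatter) and a 1.6-fold lower number from compound 2 to compound 3 (0.20 log units; within the scatter). The remaining comparison shows a 1.1-fold higher number from compound 1 to compound 2 (0.06 log units; within the scatter).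

The next structure is compound 4 `C=C(Br)C(=O)Nc1ccc(/C=C/C(=O)c2ccc(C)cc2)cc1`, with methyl in place of bromo on an aromatic carbon. Among the compounds with values here, none of the measured compounds carries methyl, so the three swaps at this same place are only an indirect guide. All three stayed within the scatter, so no step beyond it is expected in this assay, and the data suggest no firm direction. For compound 4, the estimated value is 1400 nM, with an expected range of 600 nM to 3200 nM. This estimate means an expected 1.4-fold higher number from compound 3 to compound 4 (0.15 log units; within the scatter).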

Compound 4, half-maximal inhibitory concentration: 2100 nM
Estimate against measurement, compound 4: 1.5-fold (0.18 log units) below, within the range that was stated.
By their numbers in this assay, from the lowest: compounds 3, 1, 2 and 4 (each within the scatter of the next, the first and the last beyond it).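

Methyl gives the first step at this position that lies beyond the scatter: in this assay, replacing bromo with methyl gives a 2.1-fold higher number from compound 3 to compound 4 (0.32 log units; beyond the scatter) and this step is modest. Within the data shown here, the same group shows no clear separation from the two other halogens, with a 1.3-fold higher number from compound 2 to compound 4 (0.12 log units; within the scatter) and a 1.5-fold higher number from compound 1 to compound 4 (0.18 log units; within the scatter) both staying within the scatter, so compound 4 stands apart only from compound 3 and the position so far tolerates all four groups with little change. No measured evidence here explains why the swap from bromo to methyl gives a step of this size.

Whether this position can move the number much further remains open, as all four groups shown are small. An amine, a carboxylic acid or a longer chain such as butyl in the same place could show how far that tolerance extends.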